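Acetyl Exchanged for Methoxy on Compound 2

The source may report more compounds than this note shows. Statements on the series, on what has been measured and on what is new or still open speak of the compounds shown alone.

Compound 1 `CC1(C)Oc2ccc(C#N)cc2[C@@H](/N=C(\NC#N)Oc2ccccc2)[C@@H]1O` is only bounded in a functional assay (aorta) with Rattus norvegicus as the target; on this read-out higher numbers stand for weaker inhibition and lower numbers for stronger inhibition: compound 1 gives the limit > 100000 nM. Compound 2 `CC(=O)c1ccc(N/C(=N/[C@@H]2c3cc(C#N)ccc3OC(C)(C)[C@H]2O)NC#N)cc1` gives 21000 nM in this assay, the only number shown, with an at least 4.7-fold lower number from compound 1 to compound 2 (0.67 log units; beyond the scatter) as the single measured step, which rests on (the limit of > 100000 nM in this assay, at which 1 of the 2 values shown sits). Compound 3 `COc1ccc(N/C(=N/[C@@H]2c3cc(C#N)ccc3OC(C)(C)[C@H]2O)NC#N)cc1` differs from compound 2 by methoxy in place of acetyl on an aromatic carbon. The measured step concerns a different part of the molecule and does not bear on this change, so no step beyond the scatter is expected in this assay. Compound 3 is estimated at 21000 nM, between 7000 nM and 63000 nM. The expected step is no change at the digits printed from compound 2 to compound 3 (within the scatter).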

Compound 3, half-maximal inhibitory concentration: 32500 nM
Compound 3: middle estimate off by 1.5-fold (0.19 log units), on the low side, within the range that was stated.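

In this assay the exchange of acetyl for methoxy on this aromatic carbon gives a 1.5-fold higher number from compound 2 to compound 3 (0.19 log units; within the scatter) and so the two groups are not told apart at this position. The gain over phenoxy therefore does not depend on acetyl, since (4-methoxyphenyl)amino also gives an at least 3.0-fold lower number from compound 1 to compound 3 (0.48 log units; beyond the scatter) and this step is read from a limit: the limit of > 100000 nM in this assay, at which 1 of the 3 values shown sits.

The compounds shown leave open whether an amine, a carboxylic acid or a fluorine atom on this aromatic carbon would stay level with acetyl and methoxy in this assay and whether a plain hydrogen there would do the same.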